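Shortening the chain back: what to expect of compound 4

The compounds below may be only part of what the source reports. "The series", "measured", "known", "first", "only" and "open" are said of these compounds alone.

Compound 1 `O=C(CCc1ccccc1)Nc1nc2ccccc2c(=O)s1` gives 17.6 nM in an in vitro assay on cells for inhibition of Amine oxidase [flavin-containing] B (Homo sapiens), read by fluorescence and Amplex Red, with stated times of 30 min and 45 min (a higher number here means a weaker inhibitor, a lower number a stronger inhibitor), and compound 2 `O=C(CCc1ccccc1Br)Nc1nc2ccccc2c(=O)s1` gives 2.09 nM, with an 8.4-fold lower number from compound 1 to compound 2 (0.93 log units; beyond the scatter). Compound 3 `O=C(CCCc1cccc(Cl)c1)Nc1nc2ccccc2c(=O)s1` reaches only a limit of this assay, > 1000 nM (the limit of > 1000 nM in this assay, at which 1 of the 3 values shown sits). Compound 4 `O=C(CCc1ccc(Cl)c(Cl)c1)Nc1nc2ccccc2c(=O)s1` differs from compound 3 by 3,4-dichlorophenyl in place of 3-chlorobenzyl on a saturated chain carbon, two bonds along the chain from a carbonyl carbon. Among the compounds with values here, the steps that bear on this change are an at least 56-fold higher number from compound 1 to compound 3 (1.75 log units; beyond the scatter) and an at least 470-fold higher number from compound 2 to compound 3 (2.67 log units; beyond the scatter), both large; compound 4 undoes the chain extension that separates compound 3 from the other two, and the ring keeps halogen substitution of the kind seen in an 8.4-fold lower number from compound 1 to compound 2 (0.93 log units; beyond the scatter). Compound 4 is therefore expected to show a large fall in number, an at least 120-fold lower number from compound 3 to compound 4 (2.09 log units; beyond the scatter). The estimate for compound 4 is 8 nM, expected to lie between 2 nM and 40 nM.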

Compound 4, half-maximal inhibitory concentration: > 10000 nM
Compound 4: a limit, no number; the forecaster's own chance of this, stated with the estimate: 5%; at least 1200-fold (3.09 log units) between middle value and limit.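

Compound 4 reaches only a limit of the assay: the limit of > 10000 nM in this assay, at which 1 of the 4 values shown sits. On the shorter chain, 3,4-dichlorophenyl still gives an at least 560-fold higher number from compound 1 to compound 4 (2.75 log units; beyond the scatter) and an at least 4700-fold higher number from compound 2 to compound 4 (3.67 log units; beyond the scatter), so the shorter chain alone does not bring back a low number, and halogen on this ring does not always lower it, as the bromo group did. The step from compound 3 to compound 4 cannot be read, both values being limits.

The compounds shown leave open which of the two chlorines carries the loss. They also leave open how a methoxy group or an amine on this ring would read.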